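Chalcone-Type Pyrazoles: Swapping the Aryl Ketone

The source may hold more compounds than are shown below. What is called first, only, known or untested is meant among the compounds shown, and "the series" means these compounds.

Measured so far:
compound 1, `COc1cc(-c2cc(/C=C/C(=O)c3ccc(N)cc3)[nH]n2)cc(OC)c1OC`: 9760 nM
compound 2, `COc1ccc(-c2cc(/C=C/C(=O)c3ccc(OC)c(OC)c3)[nH]n2)cc1`: 10400 nM

In a functional assay on OVCAR-8 cells (Homo sapiens) for inhibition, read by sulforhodamine B assay, with a stated time of 48 h (a higher number here means a weaker inhibitor of growth, a lower number a stronger inhibitor of growth), compound 1 gives 9760 nM, the lowest of the two numbers, while compound 2 gives 10400 nM, which lies within the scatter of compound 1, so no order between them can be read. Compound 3, `COc1cc(-c2cc(/C=C/C(=O)c3ccc(Cl)c(Cl)c3)[nH]n2)cc(OC)c1OC`, is not yet measured. It differs from compound 1 by 3,4-dichlorophenyl in place of 4-aminophenyl on a carbonyl carbon. Going by the values given here, with no step between measured compounds to lean on, a small change beyond the scatter is expected in either direction, and the step of a 1.4-fold lower number from compound 1 to compound 3 (0.14 log units; within the scatter) is estimated on that basis. For compound 3 the expected value is 7000 nM, within 2000 nM to 25000 nM.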

Compound 3, concentration for total growth inhibition: 34000 nM
For compound 3 the middle estimate is 4.9-fold (0.69 log units) below the measured one, outside the stated range (above it).
By their numbers in this assay, from the lowest: compounds 1 and 2 (each within the scatter of the next); then compound 3.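

In this assay, the group on the carbonyl carbon is shown to matter: 3,4-dichlorophenyl in place of 4-aminophenyl gives a 3.5-fold higher number from compound 1 to compound 3 (0.54 log units; beyond the scatter), so this change weakens growth inhibition. The change also takes away the hydrogen-bond donor and acceptor counted on 4-aminophenyl, but this single pair cannot separate that loss from the arrival of the two chlorines. Nothing available explains the step. Whether the amine or the chlorines account for it stays open. An unsubstituted phenyl, 4-hydroxyphenyl or 4-chlorophenyl at this place on the core of compound 1 would help to tell them apart.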